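The source may report more compounds than this note shows. Statements on the series, on what has been measured and on what is new or still open speak of the compounds shown alone.

Measured compounds:
Compound 1, `COc1cc(Nc2ncccc2-c2nc(Nc3cc(OC)ccc3OC)n[nH]2)cc(OC)c1`: 20%
Compound 2, `COc1cc(Nc2ncccc2-c2n[nH]c(Nc3cc(Cl)cc(Cl)c3)n2)cc(OC)c1`: "not determined" (no result reported)
Compound 3, `COc1cc(Nc2ncccc2-c2n[nH]c(Nc3ccc(C#N)cc3)n2)cc(OC)c1`: "not determined" (no result reported)

Among the compounds with values here, in a functional assay on A-431 cells (Homo sapiens), tested at 0.1 uM (a higher number here means more inhibition at the concentration tested (going by the name of the read-out), a lower number less inhibition), compound 1 gives 20%, and this is the only number in the set; in this assay compound 2 gives "not determined" (no result reported) and compound 3 gives "not determined" (no result reported), so nothing can be said of how they compare with compound 1. Within the data shown here, no pair of measured compounds differing in one place is available, and no step size between measured compounds can be read off.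

Compound 4, `COc1cccc(CNc2n[nH]c(-c3cccnc3Nc3cc(OC)cc(OC)c3)n2)c1`, differs from compound 1 in a single place: 3-methoxybenzyl in place of 2,5-dimethoxyphenyl on a nitrogen on an aromatic ring. Among the measured compounds shown here, with no measured step to lean on, the expectation for this change rests on compound 1 alone. The step from compound 1 to compound 4 is expected to be small, most likely not beyond the scatter of this assay, and if anything slightly downward: a number 5 percentage points lower from compound 1 to compound 4 (within the scatter). For compound 4 the estimated inhibition in this assay is 15%, with a range from 0% to 40%.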

Compound 4, a percentage reported as inhibition, at one concentration (the size of the read-out at that concentration, not a potency): 71%
For compound 4 the middle estimate is 56 percentage points below the measured one, and the stated range ends below it.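

Within this assay, the change of 2,5-dimethoxyphenyl to 3-methoxybenzyl on a nitrogen on an aromatic ring gives a number 51 percentage points higher from compound 1 to compound 4 (beyond the scatter) and is the first readable step in the set. It shows that inhibition at this position depends strongly on the group it carries, which compound 1 alone could not show. Nothing available accounts for this rise.

The change alters the group attached to the nitrogen and its methoxy substitution together, so the compounds shown leave open which of these differences matters. An unsubstituted benzyl or a 2,5-dimethoxybenzyl on this nitrogen would help to separate the two, while a 2-phenylethyl chain would address whether a longer link carries the inhibition further.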